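Series notes: the step from compound 3 to compound 4

A few compounds are considered here, and "the series" means these few. Any claim that something is new, unique, unknown or untested is made for them only; others in the source may bear on it.

Measured so far:
Compound 1 `Cc1ccc(-n2c(Nc3nc(-c4ccccc4)cs3)n[nH]c2=S)cc1`; in a functional assay on the whole organism (strain Swiss albino) for inhibition, with Mus musculus as the target, with a stated time of 4 h (a higher number here means that more compound is needed for the effect, a lower number that less compound is needed), compound 1 gives 300 mg/kg.
Compound 2 `COc1ccc(-n2c(Nc3nc(-c4ccc([N+](=O)[O-])cc4)cs3)n[nH]c2=S)cc1`; compound 2 gives 300 mg/kg.
Compound 3 `Cc1ccc(-n2c(Nc3nc(-c4ccc([N+](=O)[O-])cc4)cs3)n[nH]c2=S)cc1`; compound 3 gives 300 mg/kg.

Compound 3 stands level with compounds 1 and 2 at the digits shown. The nearest neighbour is compound 1: no change at the digits printed from compound 1 to compound 3 (within the scatter). The furthest is compound 2: no change at the digits printed from compound 2 to compound 3 (within the scatter). Neither step leaves the scatter, so the three compounds cannot be ordered on these numbers.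

Compound 4 `Cc1ccc(-n2c(Nc3nc(-c4ccc(Br)cc4)cs3)n[nH]c2=S)cc1` is not yet measured. It differs from compound 3 as follows: bromo in place of nitro on an aromatic carbon.

Among the compounds with values here, of the measured steps, only the one from compound 1 to compound 3 touches the same aromatic carbon, exchanging hydrogen for nitro, and it showed no change within the scatter. The step from compound 2 to compound 3 concerns another ring and also showed no change. Within the data shown here, no bromo analogue has been measured, so the exchange of nitro for bromo itself is untested. On this basis no shift beyond the scatter is expected in this assay: the expected step is no change at the digits printed from compound 3 to compound 4 (within the scatter). For compound 4 the expected value is 300 mg/kg, with a range of 150 mg/kg to 600 mg/kg.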

Compound 4, minimum effective dose: 300 mg/kg
Compound 4: the middle estimate sits on the measured number at the digits printed; the range from low to high includes it.
By their numbers in this assay, from the lowest: compounds 1, 2, 3 and 4 (each within the scatter of the next).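

In this assay the exchange of 4-nitrophenyl to 4-bromophenyl gives no change at the digits printed from compound 3 to compound 4 (within the scatter), so this aromatic carbon now has a second substituent to compare with nitro, and the two cannot be separated. Bromo read directly against hydrogen gives no change at the digits printed from compound 1 to compound 4 (within the scatter), which places hydrogen, nitro and bromo at this carbon within the scatter of one another and shows that, among these compounds, the reading does not depend on the hydrogen-bond acceptors of the nitro group. No independent data on these compounds bear on why the reading stays the same across these exchanges.

As far as these compounds go, all four compounds share one printed value, so it remains open whether any group at this carbon can move the minimum effective dose at all, for instance an amine, a carboxylic acid or a longer alkyl chain. From the compounds shown here alone, it also remains open whether a hydroxyl group or a halogen in place of the methyl or methoxy group on the other aromatic ring would separate from the present compounds.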